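Swapping the pyridine for a pyrazole on a sigma-1 ligand

The source may report more compounds than this note shows. Statements on the series, on what has been measured and on what is new or still open speak of the compounds shown alone.

Of the compounds shown here, three sharing one core have been measured in an assay on HEK293 cells for displacement of a labelled ligand from Sigma non-opioid intracellular receptor 1 (Homo sapiens), read by scintillation counting, with a stated time of 120 min; a lower number here means a stronger inhibitor, a higher number a weaker inhibitor. Compound 1 `Fc1ccc(-c2ncnc3c2cnn3CCN2CCCCC2)cc1` gives 95 nM, compound 2 `Clc1ccccc1-c1ncnc2c1cnn2CCN1CCCCC1` gives 76 nM, and compound 3 `Cc1cncc(-c2ncnc3c2cnn3CCN2CCCCC2)c1` gives 447 nM. Compound 3 has the highest number of the three: the step of a 4.7-fold higher number from compound 1 to compound 3 (0.67 log units; beyond the scatter) and the step of a 5.9-fold higher number from compound 2 to compound 3 (0.77 log units; beyond the scatter) both lie beyond the scatter, whereas a 1.3-fold lower number from compound 1 to compound 2 (0.10 log units; within the scatter) does not. Compound 4 `Cn1cc(-c2ncnc3c2cnn3CCN2CCCCC2)cn1` differs from compound 3 in one place: 1-methyl-1H-pyrazol-4-yl in place of 5-methylpyridin-3-yl on an aromatic carbon. The two steps that bear on this change are the ones that already swap the aryl group at this same position, and each shifted the number by a modest amount toward weaker inhibition. Among the measured compounds shown here, no measured step introduces a 1-methyl-1H-pyrazol-4-yl group, so the direction of the new step cannot be read off directly. For compound 4 a further modest rise in this assay is expected, a 1.8-fold higher number from compound 3 to compound 4 (0.25 log units; within the scatter). The estimate for compound 4 is 800 nM, with a range from 250 nM to 2500 nM.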

Compound 4, inhibition constant: 9460 nM
For compound 4 the middle estimate is 12-fold (1.07 log units) below the measured one; measured number above the stated range.
By their numbers in this assay, from the lowest: compounds 2 and 1 (each within the scatter of the next); then compound 3; then compound 4.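

In this assay this position proves far less forgiving than the earlier swaps suggested: exchanging the six-membered 5-methylpyridin-3-yl for the five-membered 1-methyl-1H-pyrazol-4-yl gives a 21-fold higher number from compound 3 to compound 4 (1.33 log units; beyond the scatter) and is a large step, where the earlier swaps were modest. Set against the phenyl groups, the same pyrazole gives a 100-fold higher number from compound 1 to compound 4 (2.00 log units; beyond the scatter) for the 4-fluorophenyl and a 120-fold higher number from compound 2 to compound 4 (2.10 log units; beyond the scatter) for the 2-chlorophenyl, so the group on this aromatic carbon can move the number much further than the first three compounds showed. No measurement at hand accounts for this loss.

Going by these compounds, it remains open whether the loss belongs to the five-membered ring or to its methyl group. A 1H-pyrazol-4-yl without the methyl, or a thiophen-3-yl, would help separate those two readings.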